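Aryl swap on the shared core: notes before measurement

A few compounds are considered here, and "the series" means these few. Any claim that something is new, unique, unknown or untested is made for them only; others in the source may bear on it.

Compound 1 `O=C1O[C@H]([C@@H](O)Cn2cc(-c3cccc(O)c3)nn2)C(OCc2ccccc2)=C1OCc1ccccc1` is the saturated, hydroxylated member of the set, and in a functional assay on HCT-116 cells (Homo sapiens) for antiproliferative activity, read by MTT assay, with a stated time of 72 h (a higher number here means a weaker inhibitor, a lower number a stronger inhibitor), compound 1 gives 42900 nM. Compound 2 `O=C1O/C(=C\Cn2cc(-c3cccc(O)c3)nn2)C(OCc2ccccc2)=C1OCc1ccccc1` is its unsaturated counterpart and in this assay compound 2 gives 63600 nM; compound 1 has the lowest of the two numbers, but the gap to compound 2 sits within the scatter, so no order between them is claimed. Compound 3 `CCCCCc1ccc(-c2cn(C/C=C3\OC(=O)C(OCc4ccccc4)=C3OCc3ccccc3)nn2)cc1` in this assay reaches only the limit > 100000 nM, and this is a limit of the assay, not a number (the limit of > 100000 nM in this assay, at which 1 of the 3 values shown sits).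

The measured step that bears on the change at hand is an at least 1.5-fold higher number from compound 2 to compound 3 (0.19 log units; that floor lies within the scatter), which shows that replacing the 3-hydroxyphenyl by an alkyl-bearing phenyl did not lower the number.

Compound 4 `Cc1ccc(-c2cn(C[C@H](O)[C@H]3OC(=O)C(OCc4ccccc4)=C3OCc3ccccc3)nn2)cc1` differs from compound 1 by 4-methylphenyl in place of 3-hydroxyphenyl on an aromatic carbon. Among the measured compounds shown here, the change resembles the one from compound 2 to compound 3 in kind but with a shorter alkyl chain. In this assay the expectation for compound 4 is therefore a higher number or none beyond the scatter, with a 1.5-fold higher number from compound 1 to compound 4 (0.18 log units; within the scatter) as the estimated step. Compound 4 is expected to give about 65000 nM, within a range of 25000 nM to 150000 nM.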

Compound 4, half-maximal inhibitory concentration: > 100000 nM
Compound 4: only a limit was reported; the forecaster's own chance of this, stated with the estimate: 30%; middle value at least 1.5-fold (0.18 log units) away from the limit.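

In this assay, the swap on the hydroxylated member of the set gives an at least 2.3-fold higher number from compound 1 to compound 4 (0.36 log units; beyond the scatter), so at this aromatic carbon of the five-membered aromatic ring with 3 nitrogen, the change from 3-hydroxyphenyl to 4-methylphenyl now reads as a real loss rather than a shift inside the noise. The earlier pair could show no more than an at least 1.5-fold higher number from compound 2 to compound 3 (0.19 log units; that floor lies within the scatter), which left open whether an alkyl-bearing phenyl cost anything at all; the new step settles that for the saturated, hydroxylated compounds only. For compound 4 the value > 100000 nM is a limit of the assay and not a number, and it is the second such value in the set: the limit of > 100000 nM in this assay, at which 2 of the 4 values shown sit.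

The step swaps 3-hydroxyphenyl, with 1 hydrogen-bond donor and 1 hydrogen-bond acceptor, for 4-methylphenyl, with 0 of each, so the compounds shown do not separate the loss of the hydroxyl from the gain of the methyl or from the shift in where the substituent sits on the phenyl. On these data alone, how a 4-hydroxyphenyl, a 3-methylphenyl, or a phenyl bearing an amine or a carboxylic acid would read at this place stays open.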